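The source may hold more compounds than are shown below. What is called first, only, known or untested is meant among the compounds shown, and "the series" means these compounds.

Compound 1 `CC1(C)N=C(N)N=C(N)N1c1cccc(OCCCOc2ccc(S(=O)(=O)F)cc2)c1` belongs to a small set of dihydrotriazines examined in an assay on isolated protein for inhibition of Dihydrofolate reductase (Mus musculus); a higher number here means a more potent compound, by a factor of ten per unit of this negative logarithm, a lower number a less potent compound. In this assay compound 1 gives 7.96. Compound 3 `CC1(C)N=C(N)N=C(N)N1c1ccc(CCCCc2ccccc2S(=O)(=O)F)c(Cl)c1` gives 7.77, a value within the usual scatter of that of compound 1; the difference between the two cores is not broken down here. Compound 2 `CC1(C)N=C(N)N=C(N)N1c1ccc(CCCCc2cc(Cl)ccc2S(=O)(=O)F)c(Cl)c1` gives 7.06, the lowest of the three measured values and beyond the scatter from both others. Compound 2 arises from compound 3 by chloro in place of hydrogen on an aromatic carbon, and that step is a number 0.71 log units lower from compound 3 to compound 2 (beyond the scatter).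

Compound 4 `CC1(C)N=C(N)N=C(N)N1c1ccc(Cl)c(OCCCOc2ccc(S(=O)(=O)F)cc2)c1` is not yet measured. It arises from compound 1 by chloro in place of hydrogen on an aromatic carbon. This is the same kind of change as that from compound 3 to compound 2, but not the same: there the chloro entered meta to a large group and para to a fluorosulfonyl group, whereas in compound 4 it enters ortho to a large group and para to a large group. Among the measured compounds shown here, because the one measured precedent, a number 0.71 log units lower from compound 3 to compound 2 (beyond the scatter), was modest, a downward step of similar or smaller size is expected, a number 0.36 log units lower from compound 1 to compound 4 (beyond the scatter). Compound 4 is therefore expected to give about 7.6 in this assay, within roughly 7 to 8.2.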

Compound 4, logarithm of the reciprocal of the active concentration, log(1/C): 7.51
Estimate against measurement, compound 4: 0.09 log units above, and the stated range covers the measured number.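

In this assay, chloro in place of hydrogen on an aromatic carbon of the core of compound 1 gives a number 0.45 log units lower from compound 1 to compound 4 (beyond the scatter), so the change again lowers the number on a second core. Two steps on two cores show that the change carried over in direction, and the data give no sign of a difference in size between them: the same change on two cores in this assay, a number 0.71 log units lower (beyond the scatter) from compound 3 to compound 2 and a number 0.45 log units lower (beyond the scatter) from compound 1 to compound 4, 0.26 log units apart, within the scatter of two such steps. They do not show that the same would hold on any other core in the series, and as the chloro does not stand in the same place in the two cases, the contribution of the core cannot be told apart from that of the place.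

The compounds shown leave open whether a fluoro or a methyl group, ortho to a large group and para to a large group, would lower the number as the chloro does. They also leave open whether the step would persist with a longer chain joining the two aromatic rings.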